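This account rests on a few compounds, and the source may have more. Where it says the series, first, only, none or still open, it means among the compounds named here.

Compound 1 `Oc1ccc(-c2cc(-c3ccccc3F)cc(-c3ccc(O)cc3)n2)cc1`: in a functional assay on HeLa cells (Homo sapiens) for inhibition (a higher number here means a weaker inhibitor, a lower number a stronger inhibitor), compound 1 gives only a limit, > 50000 nM.
Compound 2 `Oc1ccc(-c2cc(-c3ccccc3C(F)(F)F)cc(-c3ccccc3O)n2)cc1`: in this assay compound 2 gives 16500 nM.

Going by the values given here, compound 2 holds the only actual number in this assay; the other value shown is the limit (the limit of > 50000 nM in this assay, at which 1 of the 2 values shown sits). Compound 3 `Oc1ccc(-c2cc(-c3ccccc3C(F)(F)F)cc(-c3ccc(O)cc3)n2)cc1` differs from compound 2 by 4-hydroxyphenyl in place of 2-hydroxyphenyl on an aromatic carbon. Among the compounds with values here, no measured pair isolates this change, so any expected step rests on the two values alone. Compound 1, nearer in structure to compound 3, shows only a limit in this assay. The step from compound 2 to compound 3 is expected to be a loss beyond the scatter, a 2.1-fold higher number from compound 2 to compound 3 (0.33 log units; beyond the scatter). Compound 3 is estimated at 35000 nM, with a range of 10000 nM to 120000 nM, and a fair chance that only a limit is reported.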

Compound 3, half-maximal inhibitory concentration: > 50000 nM
Compound 3 gave a limit, no number; the forecaster's own chance of this, stated with the estimate: 45%; at least 1.4-fold (0.15 log units) between middle value and limit.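

With 4-hydroxyphenyl in place of 2-hydroxyphenyl on the carbon next to the ring nitrogen, the first pair isolating this change gives an at least 3.0-fold higher number from compound 2 to compound 3 (0.48 log units; beyond the scatter) in this assay. Compound 3 joins compound 1 at a limit, leaving compound 2 as the only compound with a number: the limit of > 50000 nM in this assay, at which 2 of the 3 values shown sit.

The step between the two limits, trifluoromethyl in place of fluoro, cannot be read. Open, as far as these compounds go, is whether an amine or a carboxylic acid in place of the hydroxyl of 2-hydroxyphenyl would keep a number in this assay.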